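Permeability after (pyridin-2-yl)methyl replaces phenyl on two cores

This account rests on a few compounds, and the source may have more. Where it says the series, first, only, none or still open, it means among the compounds named here.

The three measured compounds, all read in an ADME assay on Caco-2 cells (Homo sapiens) for permeability, read by LC-MS, in the apical to basolateral direction, with a stated time of 60 min, at pH 6.5; on this read-out lower numbers stand for lower permeability and higher numbers for higher permeability:
compound 1, `O=C(NCc1cc(Cl)ccc1-n1cnnn1)[C@@H]1[C@@H]2C[C@@H]2CN1C(=O)[C@H](O)Cc1ccccn1`, gives 0.62 10^-6 cm/s;
compound 2, `O=C(NCc1cc(Cl)ccc1-n1cnnn1)[C@@H]1[C@@H]2C[C@@H]2CN1C(=O)[C@H](O)c1ccccc1`, gives 2.2 10^-6 cm/s;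
compound 3, `O=C(NCc1cc(Cl)ccc1-n1cnnn1)[C@@H]1C[C@@H]2C[C@@H]2N1C(=O)[C@H](O)c1ccccc1`, gives 8 10^-6 cm/s.

Compounds 1 and 2 share one core and differ in a single place: (pyridin-2-yl)methyl in place of phenyl on a saturated chain carbon bound to a carbonyl carbon and an oxygen on a saturated carbon. That change gives a 3.5-fold lower number from compound 2 to compound 1 (0.55 log units; beyond the scatter). Compound 3 carries the same atoms as compound 2 joined differently; the difference between the two cores is not broken down here. In this assay compound 3 gives the highest number of the three, and its gaps to compound 2 and to compound 1 both lie beyond the scatter.

Compound 4, `O=C(NCc1cc(Cl)ccc1-n1cnnn1)[C@@H]1C[C@@H]2C[C@@H]2N1C(=O)[C@H](O)Cc1ccccn1`, is not yet measured. It stands to compound 3 as compound 1 stands to compound 2: (pyridin-2-yl)methyl in place of phenyl on a saturated chain carbon bound to a carbonyl carbon and an oxygen on a saturated carbon. The place is described in the same words for both pairs, so this is the same kind of change made on the other core. Among the compounds shown, this change occurs twice, once measured and once awaiting measurement.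

Among the compounds with values here, only one measured example of the change exists, so any expectation rests on it alone. Starting from compound 3, the step to compound 4 is expected to be a 3.5-fold lower number from compound 3 to compound 4 (0.54 log units; beyond the scatter), of about the size seen from compound 2 to compound 1, because that pair gave a 3.5-fold lower number from compound 2 to compound 1 (0.55 log units; beyond the scatter). On that basis compound 4 is estimated at 2.3 10^-6 cm/s in this assay, with a range from 1 10^-6 cm/s to 5 10^-6 cm/s.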

Compound 4, apparent permeability: 1.2 10^-6 cm/s
Estimate against measurement, compound 4: 1.9-fold (0.28 log units) above; the range from low to high includes it.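

On the second core, the change gives a 6.7-fold lower number from compound 3 to compound 4 (0.82 log units; beyond the scatter) in this assay, which runs in the same direction as the step on the first core. Set side by side, the two steps agree as far as these data can tell: the same change on two cores in this assay, a 3.5-fold lower number (0.55 log units; beyond the scatter) from compound 2 to compound 1 and a 6.7-fold lower number (0.82 log units; beyond the scatter) from compound 3 to compound 4, 1.9-fold (0.27 log units) apart, within the scatter of two such steps. Within the data shown here, this shows that the change carried over between these two cores with no difference in size that can be claimed, but it rests on only two pairs in a single assay, so it does not establish a rule for other cores and does not show what produces the drop.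

The change also brings in a ring nitrogen and an extra chain carbon together, and the compounds shown leave open how much each contributes; a benzyl group, with the extra carbon but no ring nitrogen, and a directly attached pyridin-2-yl group, with the ring nitrogen but no extra carbon, would separate the two. Also open, as far as these compounds go, is whether a longer chain ending in the same pyridine ring, or an amine or a carboxylic acid in the same place, would follow the same course on both cores.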